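The source may report more compounds than this note shows. Statements on the series, on what has been measured and on what is new or still open speak of the compounds shown alone.

Three compounds of the series have been run so far and share one core, carried by a piperazine nitrogen: compound 1 `CN1CCN(CC(=O)Nc2nc3ccccc3[nH]2)CC1`, compound 2 `CCN1CCN(CC(=O)Nc2nc3ccccc3[nH]2)CC1` and compound 3 `COc1ccc(N2CCN(CC(=O)Nc3nc4ccccc4[nH]3)CC2)cc1`. In a functional assay, read by spectrophotometry, with a stated time of 30 min, tested at 200 ug/mL (on this read-out higher numbers stand for a stronger effect at the one concentration tested and lower numbers for a weaker effect), compound 1 gives 61.6%. In the same read-out compound 2 gives 65.8% and compound 3 gives 63.7%. The three numbers sit close together: a number 4.2 percentage points higher from compound 1 to compound 2 (within the scatter), a number 2.1 percentage points higher from compound 1 to compound 3 (within the scatter) and a number 2.1 percentage points lower from compound 2 to compound 3 (within the scatter). Compound 3 therefore lies between the other two, and both of its steps, to compound 2 and to compound 1, are within the scatter, so no order among the three is established.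

The next compound, compound 4 `O=C(CN1CCN(c2ccc([N+](=O)[O-])cc2)CC1)Nc1nc2ccccc2[nH]1`, differs from compound 3 in one place: nitro in place of methoxy on an aromatic carbon. For the measured compounds named here, no measured step changes a group on the aryl ring itself; the two steps that reach compound 3, from compound 1 and from compound 2, exchange the whole substituent on the ring nitrogen and are each within the scatter. The nearest evidence thus shows the read-out tolerating changes at this end of the molecule without a step beyond the scatter, and no step beyond the scatter is expected for the change to nitro either. For compound 4 the step expected is a number 0.7 percentage points lower from compound 3 to compound 4 (within the scatter). Compound 4 is estimated at 63%, with a range from 50% to 76%.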

Compound 4, a percentage reported as activity, at one concentration (the size of the read-out at that concentration, not a potency): 76.7%
Beside the measured number, compound 4's estimate is 13.7 percentage points below it; the whole stated range lies below it.
By their numbers in this assay, from the lowest: compounds 1, 3 and 2 (each within the scatter of the next); then compound 4.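

In this assay, for the compounds shown here, the group on the aryl ring is the first place where a single change gives a step beyond the scatter: nitro in place of methoxy on an aromatic carbon, para to a large group, gives a number 13 percentage points higher from compound 3 to compound 4 (beyond the scatter), so this position is not as tolerant as the earlier steps suggested. Exchanging the whole substituent on the ring nitrogen stayed within the scatter in going from methyl or ethyl to 4-methoxyphenyl, but with 4-nitrophenyl it gives a number 10.9 percentage points higher from compound 2 to compound 4 (beyond the scatter) and a number 15.1 percentage points higher from compound 1 to compound 4 (beyond the scatter), so among these compounds an aryl group there does not alone set the number apart, and what the ring carries does. No measurement shown here bears on the reason for this step.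

The aryl ring carries only methoxy and nitro in these compounds, which leaves open whether the higher number is particular to nitro or would also appear with a nitrile, a trifluoromethyl group or an amine at this place. As far as these compounds go, whether the step holds at other concentrations also remains open, as the read-out comes from one concentration and is not a potency.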